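Phenylpiperidine to Difluorobenzylpiperidine: An Expected Step

The source may hold more compounds than are shown below. What is called first, only, known or untested is meant among the compounds shown, and "the series" means these compounds.

Measured so far:
- compound 1 `CCCN(CCC)c1nc(C(F)(F)F)ccc1CNC(=O)C(C)c1ccc(NS(C)(=O)=O)c(F)c1`: 14.7 nM
- compound 2 `CC(C(=O)NCc1ccc(C(F)(F)F)nc1N1CCC(c2ccccc2)CC1)c1ccc(NS(C)(=O)=O)c(F)c1`: 25 nM

Of the compounds shown here, two have been measured in a functional assay on CHO-K1 cells for antagonist activity at transient receptor potential cation channel subfamily V member 1 (Homo sapiens), read by FLIPR; a lower number here means a stronger inhibitor, a higher number a weaker inhibitor. Compound 1 `CCCN(CCC)c1nc(C(F)(F)F)ccc1CNC(=O)C(C)c1ccc(NS(C)(=O)=O)c(F)c1` gives 14.7 nM in this assay. Compound 2 `CC(C(=O)NCc1ccc(C(F)(F)F)nc1N1CCC(c2ccccc2)CC1)c1ccc(NS(C)(=O)=O)c(F)c1` gives 25 nM in this assay. Going by the values given here, the two share one core and differ at a single place, where a 4-phenylpiperidin-1-yl group stands in place of dipropylamino on an aromatic carbon; the one measured step, a 1.7-fold higher number from compound 1 to compound 2 (0.23 log units; within the scatter), lies within the scatter, so the two values cannot be told apart, and compound 2 stands alongside compound 1 rather than apart from it.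

Compound 3 `CC(C(=O)NCc1ccc(C(F)(F)F)nc1N1CCC(Cc2cc(F)cc(F)c2)CC1)c1ccc(NS(C)(=O)=O)c(F)c1` has not yet been measured. It differs from compound 2 in one place: 3,5-difluorobenzyl in place of phenyl on a saturated ring carbon. Among the compounds with values here, no measured step touches this part of the molecule; the only step available swapped the whole amine group and was itself within the scatter, so it offers no lead on the direction of this change. The expectation is therefore no step beyond the scatter, no change at the digits printed from compound 2 to compound 3 (within the scatter). For compound 3 the estimate in this assay is 25 nM, with a range from 8 nM to 80 nM.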

Compound 3, half-maximal inhibitory concentration: 24 nM
Beside the measured number, compound 3's estimate is 1.0-fold (0.02 log units) above it, and the stated range covers the measured number.
By their numbers in this assay, from the lowest: compounds 1, 3 and 2 (each within the scatter of the next).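

In this assay, the step of a 1.0-fold lower number from compound 2 to compound 3 (0.02 log units; within the scatter) shows that the number holds when phenyl, with 6 heavy atoms, gives way to 3,5-difluorobenzyl, with 9 heavy atoms, on this saturated ring carbon three ring bonds from the ring nitrogen. Going by these compounds alone, the earlier step replaced the whole amine group, so this is the first look at a change made further out, on the six-membered non-aromatic ring itself. Nothing measured here explains why the number holds across this change.

This single step changes two things at once, adding a carbon link and two fluorines, so the compounds shown leave open what each contributes alone, which an unsubstituted benzyl group would help to separate. They also leave open whether this ring carbon would accept a quite different group, such as a carboxylic acid, an amine or a longer chain such as 2-phenylethyl, with the number still unchanged.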